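The source may report more compounds than this note shows. Statements on the series, on what has been measured and on what is new or still open speak of the compounds shown alone.

Three compounds sharing one core carry a benzoyl amide and a fluorinated benzyl group on the ring amine. Compound 1 `CC1(C)c2[nH]nc(NC(=O)c3ccccc3)c2CN1Cc1cccc(F)c1F` bears a 2,3-difluorobenzyl group; in an assay on Sf21 cells for inhibition of high affinity nerve growth factor receptor (Homo sapiens), read by HTRF, with a stated time of 30 min, in the presence of a further agent that is not named here (a higher number here means a weaker inhibitor, a lower number a stronger inhibitor), compound 1 gives 200 nM. Compound 2 `CC1(C)c2[nH]nc(NC(=O)c3ccccc3)c2CN1Cc1ccc(F)c(F)c1` differs from compound 1 in how the same atoms are joined: 2,3-difluorophenyl in place of 3,4-difluorophenyl on a saturated chain carbon bound to an amine nitrogen in a ring. In this assay compound 2 gives 680 nM, so the step of a 3.4-fold higher number from compound 1 to compound 2 (0.53 log units; beyond the scatter) is beyond the scatter. Compound 3 `CC1(C)c2[nH]nc(NC(=O)c3ccccc3)c2CN1Cc1cc(F)c(F)c(F)c1` adds one more fluorine to compound 2: fluoro in place of hydrogen on an aromatic carbon. In this assay compound 3 gives 6960 nM, a step of a 10-fold higher number from compound 2 to compound 3 (1.01 log units; beyond the scatter), and from compound 1 the step is a 35-fold higher number from compound 1 to compound 3 (1.54 log units; beyond the scatter).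

Compound 4 `CC1(C)c2[nH]nc(NC(=O)c3ccc(F)cc3)c2CN1Cc1cccc(F)c1F` is not yet measured. It differs from compound 1 by fluoro in place of hydrogen on an aromatic carbon. This is the same kind of change as that from compound 2 to compound 3, but the surroundings differ: in compound 4 the new fluoro sits para to a large group on the benzoyl ring, whereas in compound 3 it sits ortho to a fluoro group, meta to a fluoro group and meta to a large group on the benzyl ring. Within the data shown here, the single measured instance of this kind of change, a 10-fold higher number from compound 2 to compound 3 (1.01 log units; beyond the scatter), lies on a different ring. It gives only weak grounds for expecting a large loss in compound 4. Compound 4 is therefore expected to show only a small step, a 1.5-fold higher number from compound 1 to compound 4 (0.18 log units; within the scatter), in this assay, and its value is estimated at 300 nM, between 120 nM and 800 nM.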

Compound 4, half-maximal inhibitory concentration: 210 nM
Beside the measured number, compound 4's estimate is 1.4-fold (0.15 log units) above it, within the range that was stated.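

In this assay, putting a fluoro in place of hydrogen on the benzoyl ring of compound 1, para to a large group, gives a 1.1-fold higher number from compound 1 to compound 4 (0.02 log units; within the scatter), so compound 1 and compound 4 cannot be told apart on this read-out. The same kind of change therefore does not carry over as a step of fixed size, since its earlier instance on the benzyl ring was far larger: the same change on two cores in this assay, a 10-fold higher number (1.01 log units; beyond the scatter) from compound 2 to compound 3 and a 1.1-fold higher number (0.02 log units; within the scatter) from compound 1 to compound 4, 9.7-fold (0.99 log units) apart, beyond the scatter of two such steps What this does not show is which difference between the two pairs accounts for the gap, since compound 4 and compound 3 differ both in the ring that takes the new fluoro and in the benzyl group already present, and with one pair for each case the two cannot be separated, nor can a rule be drawn for either ring.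

The compounds shown leave open whether the 4-fluorophenyl amide would give an equally small step when paired with the 3,4-difluorophenyl group of compound 2. They also leave open how this assay would respond to an amine, a carboxylic acid or a longer chain in the same place on the benzoyl ring.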